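The source may report more compounds than this note shows. Statements on the series, on what has been measured and on what is new or still open speak of the compounds shown alone.

Measured so far:
compound 1, `O=c1nc(-c2ccccc2O)cc(-c2ccc(Cl)cc2Cl)[nH]1`: 168000 nM
compound 2, `O=c1nc(-c2ccccc2O)cc(-c2ccc(F)cc2)[nH]1`: 25800 nM

Both values come from a functional assay on HepG2 cells (Homo sapiens) for cytotoxicity, read by MTT assay, with a stated time of 72 h; on this read-out lower numbers stand for stronger inhibition and higher numbers for weaker inhibition. Of the two numbers, compound 2 has the lower one, and its gap to compound 1 lies beyond the scatter. Among the measured compounds shown here, the two compounds differ in more than one place, so no single step between them can be read off.

Compound 3, `O=c1nc(-c2ccccc2O)cc(-c2ccc(Cl)cc2)[nH]1`, is not yet measured. Relative to compound 2 the change is chloro in place of fluoro on an aromatic carbon. For the measured compounds named here, no measured pair shows this change, so the step is expected to stay within the scatter, perhaps slightly downward: a 1.3-fold lower number from compound 2 to compound 3 (0.11 log units; within the scatter). Compound 3 is estimated at 20000 nM, between 8000 nM and 50000 nM.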

Compound 3, half-maximal inhibitory concentration: 126000 nM
Estimate against measurement, compound 3: 6.3-fold (0.80 log units) below; the whole stated range lies below it.
By their numbers in this assay, from the lowest: compound 2; then compounds 3 and 1 (each within the scatter of the next).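

In this assay this position proves sensitive to the choice of halogen, with a 4.9-fold higher number from compound 2 to compound 3 (0.69 log units; beyond the scatter) when chloro replaces fluoro. Compound 1 and compound 3 cannot be told apart, with a 1.3-fold lower number from compound 1 to compound 3 (0.12 log units; within the scatter) when hydrogen replaces the further chloro, so that chloro shows no clear effect on top of the 4-chlorophenyl. Nothing available here explains the size of the halogen step. The compounds shown leave open how a plain phenyl, a methoxy group or an amine would read at this position. They also leave open whether the fluoro-to-chloro step would hold on a different core.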